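Removing the Urea Cap from an Acylsulfonamide Chain

A few compounds are considered here, and "the series" means these few. Any claim that something is new, unique, unknown or untested is made for them only; others in the source may bear on it.

Compound 1 `O=C(NS(=O)(=O)CCNC(=O)C1CC1)c1ccc(Nc2nc(NC3(c4ccc(Cl)cc4)CC3)nc(OCC(F)(F)F)n2)cc1`: 1 nm/s
Compound 2 `CNC(=O)NCCS(=O)(=O)NC(=O)c1ccc(Nc2nc(NC3(c4ccc(Cl)cc4)CC3)nc(OCC(F)(F)F)n2)cc1`: 40 nm/s
Compound 3 `NCCS(=O)(=O)NC(=O)c1ccc(Nc2nc(NC3(c4ccc(Cl)cc4)CC3)nc(OCC(F)(F)F)n2)cc1`: not yet measured

In a physicochemical assay for permeability, using PAMPA, at pH 7.4 (on this read-out lower numbers stand for lower permeability and higher numbers for higher permeability), compound 2 gives 40 nm/s, the higher of the two numbers recorded so far. Among the measured compounds shown here, its only neighbour is compound 1, and the change between them was a 40-fold higher number from compound 1 to compound 2 (1.60 log units; beyond the scatter). Compound 3 differs from compound 2 by hydrogen in place of methylcarbamoyl on an amine nitrogen. For the measured compounds named here, no measured step touches that amine nitrogen: the one step known alters the carbonyl carbon further along the same chain, and the pair of compounds 1 and 2 therefore bears on compound 3 only as a sign that this region of the molecule can move the read-out strongly. Since nothing in the two measurements shows what taking the methylcarbamoyl group off does, the expectation for compound 3 is set with a wide range, a 5.0-fold lower number from compound 2 to compound 3 (0.70 log units; beyond the scatter), giving an estimated 8 nm/s between 1 nm/s and 60 nm/s.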

Compound 3, apparent permeability: 153 nm/s
Estimate against measurement, compound 3: 19-fold (1.28 log units) below, outside the stated range (above it).
By their numbers in this assay, from the lowest: compound 1; then compound 2; then compound 3.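

In this assay, taking the group off the amine nitrogen raises the number instead of lowering it: replacing methylcarbamoyl with hydrogen gives a 3.8-fold higher number from compound 2 to compound 3 (0.58 log units; beyond the scatter), and replacing cyclopropylcarbonyl with hydrogen gives a 150-fold higher number from compound 1 to compound 3 (2.18 log units; beyond the scatter). The amine nitrogen itself is therefore a place where this read-out moves, and both substituted compounds stand below compound 3, with the size of the gain depending on which group leaves. Nothing available explains why the number rises when either group is removed.

The compounds shown leave open whether a single methyl group or an acetyl group on this amine nitrogen would stay close to compound 3 or fall back toward compound 2. They also leave open whether a longer chain in place of 2-aminoethyl would keep the higher number.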